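Replacing a trifluoromethylpyrazole with a fused ring

This account rests on a few compounds, and the source may have more. Where it says the series, first, only, none or still open, it means among the compounds named here.

Compound 3 `CCCC(Oc1ccc(-n2cc(C(F)(F)F)cn2)cc1)c1ccc(C(=O)NCCC(=O)O)cc1` gives 2.4 in a physicochemical assay for lipophilicity, using the shake flask method, at pH 7.4 (on this read-out lower numbers stand for lower lipophilicity and higher numbers for higher lipophilicity), the second highest of the three numbers measured. Its nearest neighbour is compound 1 `CCCC(Oc1ccc(-n2cc(Cl)cn2)cc1)c1ccc(C(=O)NCCC(=O)O)cc1` with 2.6, the step of a number 0.20 log units lower from compound 1 to compound 3 (within the scatter); the furthest is compound 2 `CCCC(Oc1ccc(-n2cc(C(=O)N(C)C)cn2)cc1)c1ccc(C(=O)NCCC(=O)O)cc1` with 0.5, the step of a number 1.90 log units higher from compound 2 to compound 3 (beyond the scatter). Compound 4 `CCCC(Oc1ccc(-n2cc3c(n2)CCCC3)cc1)c1ccc(C(=O)NCCC(=O)O)cc1` has not been measured; it differs from compound 3 in this way: a group of 9 heavy atoms (7 carbon, 2 nitrogen; one five-membered aromatic ring with 2 hetero atoms, one six-membered non-aromatic ring of carbon only) in place of a group of 9 heavy atoms (4 carbon, 2 nitrogen, 3 fluorine; one five-membered aromatic ring with 2 hetero atoms), on an aromatic carbon. Of the known steps, a number 2.10 log units lower from compound 1 to compound 2 (beyond the scatter) and a number 1.90 log units higher from compound 2 to compound 3 (beyond the scatter) show that what sits on the pyrazole can move the number a great deal, while a number 0.20 log units lower from compound 1 to compound 3 (within the scatter) shows a swap that barely moves it. The change to compound 4 resembles neither swap closely, so compound 4 is expected to give 2.8 (between 2.3 and 3.3), a step of a number 0.40 log units higher from compound 3 to compound 4 (beyond the scatter) estimated from compound 3.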

Compound 4, distribution coefficient: 2.7
Compound 4: middle estimate off by 0.10 log units, on the high side, within the range that was stated.
By their numbers in this assay, from the lowest: compound 2; then compounds 3, 1 and 4 (each within the scatter of the next).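

In this assay, the entering group, with its six-membered non-aromatic ring of carbon only, replaces 4-(trifluoromethyl)-1H-pyrazol-1-yl with a number 0.30 log units higher from compound 3 to compound 4 (within the scatter), so a group without fluorine reads level with the trifluoromethyl group at this place. The comparison with the chloro group reads the same, a number 0.10 log units higher from compound 1 to compound 4 (within the scatter), while a number 2.20 log units higher from compound 2 to compound 4 (beyond the scatter) leaves the dimethylcarbamoyl compound alone at the low end. Nothing available gives a reason for these numbers. The compounds shown leave open how an amine or a carboxylic acid on the non-aromatic ring would move the number.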